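This account rests on a few compounds, and the source may have more. Where it says the series, first, only, none or still open, it means among the compounds named here.

Measured in an ADME assay on Raji cells (Homo sapiens) for cytotoxicity, with a stated time of 72 h; on this read-out lower numbers stand for an effect already at smaller amounts and higher numbers for an effect only at larger amounts of compound:

- Compound 1 `Cc1ccc(-c2nc3ccccc3s2)cc1NC(=O)c1cc([N+](=O)[O-])c(N(C)C)cc1Cl`: > 25000 nM, a limit
- Compound 2 `Cc1cc(NC(=O)c2cc([N+](=O)[O-])ccc2Cl)cc(-c2nc3ccccc3o2)c1O`: > 25000 nM, a limit
- Compound 3 `O=C(Nc1ccc(O)c(-c2nc3ccccc3s2)c1)c1cc([N+](=O)[O-])ccc1Cl`: > 25000 nM, a limit

Compound 1 gives no exact number in this assay. Its result of > 25000 nM is a limit of the assay. For the measured compounds named here, compound 1 therefore stands with the other two measured compounds, and the series so far sits at the limit of > 25000 nM in this assay, at which 3 of the 3 values shown sit. With only limits in hand, no size of change can be read between any two of these compounds, and no measured step is available as a guide.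

The compound still to be measured is compound 4 `Cc1ccc(-c2nc3ccccc3s2)cc1NC(=O)c1cc([N+](=O)[O-])c(N2CCCCC2)cc1Cl`. It keeps the core of compound 1 and changes one group: piperidin-1-yl in place of dimethylamino on an aromatic carbon, ortho to a nitro group (piperidin-1-yl in place of dimethylamino on an aromatic carbon).

No step beyond the usual scatter is expected in this assay, in either direction. This expectation rests on compound 1 and its limit of > 25000 nM. The expected change is a number no higher from compound 1 to compound 4 (the limit leaves the size open), and the most likely outcome is another limit rather than an exact number. For compound 4 the estimated value is 25000 nM, with an expected range from 12000 nM to 50000 nM.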

Compound 4, half-maximal effective concentration: > 25000 nM
Compound 4: no number, only a limit; the forecaster's own chance of this, stated with the estimate: 80%; the middle value sits exactly at the limit.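

In this assay compound 4 gives > 25000 nM, which is a limit and not a number. Compound 1 also stands at a limit, and no step can be read between compound 1 and compound 4. The compounds shown leave open whether piperidin-1-yl in place of dimethylamino changes the read-out at all, with every result at one limit: the limit of > 25000 nM in this assay, at which 4 of the 4 values shown sit.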